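Swapping 2-fluorophenyl for 4-ethoxy-2-methylphenyl: an expected rise

The compounds below may be only part of what the source reports. "The series", "measured", "known", "first", "only" and "open" are said of these compounds alone.

Values so far in a physicochemical assay for lipophilicity, read by HPLC, in phosphate buffer, measured as octanol-water partition, at pH 7.4, tested at 100 uM (a lower number here means a more polar compound, a higher number a more lipophilic compound), by compound:
- Compound 1 `Cc1cc(OCCCS(C)(=O)=O)cc(C)c1-c1cccc(CNc2ccc(OCC(=O)O)c(F)c2)c1` gives 1.73
- Compound 2 `O=C(O)COc1ccc(NCc2cccc(-c3ccccc3F)c2)cc1F` gives 2.36
- Compound 3 `N#Cc1ccccc1-c1cccc(CNc2ccc(OCC(=O)O)c(F)c2)c1` gives "not determined" (no result reported)

Compound 2 holds the higher of the two available numbers, and compound 1 lies below it by more than the usual scatter of repeated measurements. Compound 3 offers no number for comparison.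

The account now turns to compound 4 `CCOc1ccc(-c2cccc(CNc3ccc(OCC(=O)O)c(F)c3)c2)c(C)c1`, which has not yet been measured. It carries 4-ethoxy-2-methylphenyl in place of the 2-fluorophenyl of compound 2, on an aromatic carbon, meta to a large group 4-ethoxy-2-methylphenyl in place of 2-fluorophenyl on an aromatic carbon and the rest of the structure stays the same. Among the compounds with values here, no measured pair differs in one place only, so no observed step can serve as a guide, and the expectation rests on the structural change alone. The entering group has more heavy atoms, and an oxygen where the leaving group has a fluorine. Starting from compound 2 at 2.36 the expectation in this assay is a rise beyond the scatter. The estimated change is a number 0.54 log units higher from compound 2 to compound 4 (beyond the scatter) and remains an expectation only. Compound 4 is expected at 2.9 with 2.5 to 3.3 as the estimated range.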

Compound 4, distribution coefficient: 2.83
Estimate against measurement, compound 4: 0.07 log units above, and the stated range covers the measured number.
By their numbers in this assay, from the lowest: compound 1; then compound 2; then compound 4.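

In this assay, within the data shown here, the exchange of 2-fluorophenyl for 4-ethoxy-2-methylphenyl on an aromatic carbon, meta to a large group, gives a number 0.47 log units higher from compound 2 to compound 4 (beyond the scatter) and is the first step at this position that can be read from compounds differing in one place. The entering group has 10 heavy atoms against 7 in the leaving group and brings 1 hydrogen-bond acceptor where the leaving group has 0, and the number still moves upward beyond the scatter. Nothing measured here gives a cause for this step.

On these data alone, the ethoxy, the methyl and the departure of the fluorine all change together in this one step, and the share of each in the rise stays open. As far as these compounds go, how the number would respond to an amine or a carboxylic acid on this ring, or to a longer chain in place of the ethoxy, also stays open.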